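The compounds below may be only part of what the source reports. "The series", "measured", "known", "first", "only" and "open" are said of these compounds alone.

Measured so far in a functional assay on A20 cells (Mus musculus) for inhibition, with stated times of 1 h, 16 h and 24 h; a lower number here means a stronger inhibitor, a higher number a weaker inhibitor:
compound 1 `CN1CCN(C(=O)[C@@H]2C[C@H](S(=O)(=O)c3ccccc3)C[C@H]2C(=O)NC2(C#N)CC2)CC1`: 17 nM
compound 2 `N#CC1(NC(=O)[C@@H]2C[C@@H](S(=O)(=O)c3ccccc3)C[C@H]2C(=O)N2CC(O)C2)CC1`: 572 nM

For the measured compounds named here, compound 2 is the weaker inhibitor of the pair, and compound 1 is its only neighbour on the scale. The next compound to be read is compound 3 `CN(C)C(=O)[C@@H]1C[C@H](S(=O)(=O)c2ccccc2)C[C@H]1C(=O)NC1(C#N)CC1`, and the change from compound 2 is dimethylamino in place of 3-hydroxyazetidin-1-yl on a carbonyl carbon. In words, dimethylamino stands in place of 3-hydroxyazetidin-1-yl on a carbonyl carbon.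

Going by the values given here, only one measured step bears on this place: a 34-fold higher number from compound 1 to compound 2 (1.53 log units; beyond the scatter), a large step, made when 3-hydroxyazetidin-1-yl replaced 4-methylpiperazin-1-yl. It shows that the number in this assay can move far with the group carried here, but one step cannot rank dimethylamino. The 4-methylpiperazin-1-yl group of compound 1, at 17 nM, is absent from compound 3, so no return to that level is expected. A small move towards a lower number is expected instead, probably not clear of the scatter. This estimate means an expected 1.9-fold lower number from compound 2 to compound 3 (0.28 log units; within the scatter). For compound 3 the estimated value is 300 nM, with an expected range of 100 nM to 900 nM.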

Compound 3, half-maximal inhibitory concentration: 91 nM
Compound 3: middle estimate off by 3.3-fold (0.52 log units), on the high side; measured number below the stated range.
By their numbers in this assay, from the lowest: compound 1; then compound 3; then compound 2.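

In this assay the step to dimethylamino on this carbonyl carbon gives a 6.3-fold lower number from compound 2 to compound 3 (0.80 log units; beyond the scatter), so this position does not need a ring for the number to fall, and the group with fewer heavy atoms and no hydrogen-bond donor is the stronger of the two. The move to dimethylamino still leaves a 5.4-fold higher number from compound 1 to compound 3 (0.73 log units; beyond the scatter), so the 4-methylpiperazin-1-yl group keeps the lowest number and the three groups now fall into an order, with every step between them beyond the scatter. No measurement here accounts for this order.

The three compounds change several features at once, so the 3-hydroxyazetidin-1-yl result cannot be divided between its hydroxyl and its four-membered ring, and the unsubstituted azetidin-1-yl group would separate the two. Likewise, the lower number of compound 1 cannot yet be assigned to the ring, the second ring nitrogen or its methyl, a question that the piperidin-1-yl and morpholin-4-yl groups, which carry a carbon and an oxygen in place of that nitrogen, would bear on.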